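Working notes: from compound 2 to compound 3

The source may report more compounds than this note shows. Statements on the series, on what has been measured and on what is new or still open speak of the compounds shown alone.

Measured so far in an in vivo ADME assay on the whole organism (Cavia porcellus) (on this read-out lower numbers stand for a shorter-lived compound and higher numbers for a longer-lived compound), on this series:
- compound 1 `CCOC(=O)CC1CCN(C(=O)C(C)(C)C(CC)NC(=O)c2ccc(C(=N)N3CCC(O)CC3)cc2F)CC1` gives 3.5 h here
- compound 2 `CCOC(=O)CC1CCN(C(=O)C(C)(C)C(CC)NC(=O)c2ccc(C(=N)N3CCN(C)CC3)cc2F)CC1` gives 1.77 h here

Compound 2 stands within the scatter of compound 1, so the two numbers do not separate. Within the data shown here, the one measured step is a 2.0-fold lower number from compound 1 to compound 2 (0.30 log units; within the scatter) and it brings 4-methylpiperazin-1-yl in place of 4-hydroxypiperidin-1-yl on a carbon with a double bond to nitrogen.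

Compound 3 `CCOC(=O)CC1CCN(C(=O)C(C)(C)C(CC)NC(=O)c2ccc(C(=N)N3CCN(c4ccc(F)cc4)CC3)cc2F)CC1` has not been measured yet. Its change from compound 2 is 4-fluorophenyl in place of methyl on an amine nitrogen in a ring, counted as 4-fluorophenyl in place of methyl on an amine nitrogen in a ring for this exchange. Among the measured compounds shown here, that step bears on it only loosely, since no measured compound tests this exchange. For the measured compounds named here, the expectation therefore starts from compound 2 at 1.77 h and takes the size of the one measured step as its only guide, so no change beyond the scatter is expected in this assay for now. The expected size is a 1.2-fold higher number from compound 2 to compound 3 (0.09 log units; within the scatter) in this estimate. For compound 3 the estimated value is 2.2 h with an expected range from 1 h to 5 h on this read-out.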

Compound 3, half-life: 0.417 h
Compound 3: the middle estimate sits 5.3-fold (0.72 log units) above what was measured; measured number below the stated range.
By their numbers in this assay, from the lowest: compound 3; then compounds 2 and 1 (each within the scatter of the next).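

In this assay, among these compounds, the substituent on the amine nitrogen in the ring matters: 4-fluorophenyl in place of methyl gives a 4.2-fold lower number from compound 2 to compound 3 (0.63 log units; beyond the scatter), the only step so far that lies beyond the scatter. Compounds 1 and 2 differ in the whole group on the carbon with a double bond to nitrogen and do not separate, so they left this nitrogen untested; the new step shows that the half-life can move with a change at this one atom. No measurement on these compounds gives a cause for the step.

A single exchange cannot tell whether the number follows the aromatic ring, its fluorine or simply the larger group, so phenyl without fluorine, benzyl and ethyl on the same nitrogen would each be informative. Going by these compounds, it also remains open whether an acetyl or 2-hydroxyethyl group there would lower the number as the 4-fluorophenyl group does or keep it close to that of compound 2 at 1.77 h.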